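Aminothiophene ketones: pyridin-4-yl for pyrimidin-5-yl

This account rests on a few compounds, and the source may have more. Where it says the series, first, only, none or still open, it means among the compounds named here.

Three compounds of the series have numbers in an assay on CHO cells for positive allosteric modulation of adenosine receptor A1 (Homo sapiens), read by ERK phosphorylation, tested at 10 uM; on this read-out higher numbers stand for a weaker effect at the one concentration tested and lower numbers for a stronger effect. Compound 1 `Nc1sc(-c2ccncc2)cc1C(=O)c1ccccc1` gives 17%. Compound 2 `Nc1sc(-c2ccccc2)cc1C(=O)c1ccc(Cl)cc1` gives 16%. Compound 3 `Nc1sc(-c2cncnc2)cc1C(=O)c1ccc(Cl)cc1` gives 4%, the lowest and therefore the strongest of the three, its gaps to compound 2 and to compound 1 both lying beyond the scatter. Within the data shown here, the single measured step that bears on the ring pair is a number 12 percentage points lower from compound 2 to compound 3 (beyond the scatter).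

Compound 4 `Nc1sc(-c2ccncc2)cc1C(=O)c1ccc(Cl)cc1` is the next member to be measured. Relative to compound 3 the change is pyridin-4-yl in place of pyrimidin-5-yl on an aromatic carbon. Among the measured compounds shown here, no measured step covers this exchange directly. Compound 1, which carries pyridin-4-yl, and compound 2, which carries phenyl, give numbers within the scatter of each other, though the two also differ in the chloro on the benzoyl ring, so that comparison is indirect. On that basis compound 4 is expected to move back toward the phenyl level, with a step of a number 8 percentage points higher from compound 3 to compound 4 (within the scatter) expected in this assay. The estimate for compound 4 is 12%, with a range from 4% to 22%.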

Compound 4, a percentage reported as activity, at one concentration (the size of the read-out at that concentration, not a potency): 17%
For compound 4 the middle estimate is 5 percentage points below the measured one; the measured number falls inside the stated range.
By their numbers in this assay, from the lowest: compound 3; then compounds 2, 1 and 4 (each within the scatter of the next).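

In this assay, the exchange on the aromatic carbon next to the ring sulfur can now be read directly with the chloro benzoyl group held constant (a number 13 percentage points higher from compound 3 to compound 4 (beyond the scatter)), and the comparison with phenyl gives a second step (a number 1 percentage points higher from compound 2 to compound 4 (within the scatter)). Among these three rings, only pyrimidin-5-yl stands apart, with compound 3 separated from both compound 2 and compound 4. The chloro can also be read on its own with pyridin-4-yl in place (no change at the digits printed from compound 1 to compound 4 (within the scatter)), and no evidence at hand explains the difference between pyrimidin-5-yl and pyridin-4-yl.

Going by these compounds, whether the chloro counts for as little alongside pyrimidin-5-yl remains open. Also open, on these data alone, is how other rings at this position, such as pyridin-3-yl or pyrazin-2-yl, would compare with pyrimidin-5-yl.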